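Adding a nitro group to compound 3

The compounds below may be only part of what the source reports. "The series", "measured", "known", "first", "only" and "open" are said of these compounds alone.

In a functional assay on SH-SY5Y cells (Homo sapiens) for cytotoxicity, read by MTT assay, with a stated time of 72 h (on this read-out higher numbers stand for weaker inhibition and lower numbers for stronger inhibition), compound 1 `CCCC[S+]([O-])CCCCN=C=S` gives 6470 nM and compound 2 `[O-][S+](CCCCN=C=S)c1ccccc1` gives 8750 nM in the same test. Compound 3 `[O-][S+](CCCCN=C=S)Cc1ccccc1` gives 5210 nM and lies within the scatter of both. Compound 4 `O=[N+]([O-])c1ccc(C[S+]([O-])CCCCN=C=S)cc1` carries one change from compound 3, nitro in place of hydrogen on an aromatic carbon, para to a large group (nitro in place of hydrogen on an aromatic carbon). Among the measured compounds shown here, no measured pair shows this change directly. With compound 2 at 8750 nM within the scatter of compound 3 at 5210 nM despite their different groups, only a small shift toward a lower number is expected. The estimated move is a 1.3-fold lower number from compound 3 to compound 4 (0.11 log units; within the scatter) and it would stay within the scatter. For compound 4 the expected value is 4000 nM within a range of 1800 nM to 9000 nM by this estimate.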

Compound 4, half-maximal inhibitory concentration: 7230 nM
Beside the measured number, compound 4's estimate is 1.8-fold (0.26 log units) below it; the range from low to high includes it.
By their numbers in this assay, from the lowest: compounds 3, 1, 4 and 2 (each within the scatter of the next).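

In this assay, among the compounds shown here, nitro in place of hydrogen on an aromatic carbon, para to a large group, gives a 1.4-fold higher number from compound 3 to compound 4 (0.14 log units; within the scatter), the first direct reading of this change. This single pair shows that the position accepts nitro with no shift beyond the scatter. Nothing available bears on why the number stays there. The compounds shown leave open whether an amine or a methoxy group at this same place would also stay within the scatter. They also leave open whether nitro elsewhere on the aromatic ring would do the same.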